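Enlarging the thiazole amide: from compound 1 to compound 3

A few compounds are considered here, and "the series" means these few. Any claim that something is new, unique, unknown or untested is made for them only; others in the source may bear on it.

Measured compounds:
compound 1, `O=C(CCCCCCNC(=O)C(O)(O)C(F)(F)F)Nc1nccs1`: 10800 nM
compound 2, `O=C(CCCCCCNC(=O)C(O)(O)C(F)(F)F)Nc1nc2ccccc2s1`: 2370 nM

In a functional assay on HCT-116 cells (Homo sapiens) for inhibition, read by colorimetric assay, with a stated time of 3 days (a higher number here means a weaker inhibitor, a lower number a stronger inhibitor), compound 1 gives 10800 nM, the highest of the two numbers; its nearest neighbour is compound 2, which gives 2370 nM. Among the compounds with values here, the single measured step, a 4.6-fold lower number from compound 1 to compound 2 (0.66 log units; beyond the scatter), is the only guide available, and it replaces the whole ring rather than adding a group to it. Compound 3, `CCOc1ccc(-c2cnc(NC(=O)CCCCCCNC(=O)C(O)(O)C(F)(F)F)s2)cc1`, carries 4-ethoxyphenyl in place of hydrogen on an aromatic carbon on the core of compound 1. Both the measured step and this change make the group on the amide nitrogen larger, so a lower number is expected, though the change is not the same and a step within the scatter remains possible. The expected step is a 3.1-fold lower number from compound 1 to compound 3 (0.49 log units; beyond the scatter). Compound 3 is therefore estimated at 3500 nM, within a range of 1000 nM to 12000 nM.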

Compound 3, half-maximal inhibitory concentration: 4050 nM
Beside the measured number, compound 3's estimate is 1.2-fold (0.06 log units) below it, within the range that was stated.
By their numbers in this assay, from the lowest: compounds 2 and 3 (each within the scatter of the next); then compound 1.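

In this assay, placing 4-ethoxyphenyl on the aromatic carbon next to the ring sulfur gives a 2.7-fold lower number from compound 1 to compound 3 (0.43 log units; beyond the scatter) and so moves the number beyond the scatter. The earlier compounds shown here showed only the replacement of the whole ring, whereas this is a change at one ring carbon of the core of compound 1, and it shows that this position takes a large aromatic group without the number rising. No measurement shown here accounts for the step.

Within the data shown here, only one group stands at this position, so it remains open whether the phenyl ring alone or the ethoxy group on it carries the step. A bare phenyl, a methoxy group in place of the ethoxy, or an amine or a carboxylic acid on the phenyl ring would separate these parts.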